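Hydroxy for Chloro on Two Differently Placed Aryl Rings

The source may hold more compounds than are shown below. What is called first, only, known or untested is meant among the compounds shown, and "the series" means these compounds.

Compound 1 `CC[C@]1(c2ccccc2Cl)OC[C@H]([C@@H]2CCCCN2)O1` and compound 2 `CC[C@]1(c2ccc(Cl)cc2)OC[C@H]([C@@H]2CCCCN2)O1` have the same atoms joined differently; the difference between the two cores is not broken down here. In a functional assay (brain) for displacement of a labelled ligand, with Rattus norvegicus as the target (a lower number here means a stronger inhibitor, a higher number a weaker inhibitor), compound 1 gives 14.3 nM, whereas compound 2 gives 2800 nM, the highest of the three measured numbers. Compound 3 `CC[C@]1(c2ccccc2O)OC[C@H]([C@@H]2CCCCN2)O1` arises from compound 1 through (hydroxy in place of chloro on an aromatic carbon), and in this assay compound 3 gives 293 nM, a step of a 20-fold higher number from compound 1 to compound 3 (1.31 log units; beyond the scatter). Compound 4 `CC[C@]1(c2ccc(O)cc2)OC[C@H]([C@@H]2CCCCN2)O1` arises from compound 2 through (hydroxy in place of chloro on an aromatic carbon). This is the same kind of change, but the place differs: ortho to a large group in the first pair, para to a large group in the second. Compound 4 is expected to show a step of an 11-fold higher number from compound 2 to compound 4 (1.03 log units; beyond the scatter) in this assay, resting on the step of a 20-fold higher number from compound 1 to compound 3 (1.31 log units; beyond the scatter) and on the starting value of compound 2 2800 nM. Compound 4 is therefore estimated at 30000 nM, between 5000 nM and 200000 nM.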

Compound 4, inhibition constant: 19900 nM
The estimate for compound 4 lay 1.5-fold (0.18 log units) above the measured number; the measured number falls inside the stated range.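

In this assay, hydroxy in place of chloro on an aromatic carbon again gives a weaker inhibitor, with a 7.1-fold higher number from compound 2 to compound 4 (0.85 log units; beyond the scatter) and the same direction as on the core of compound 1. The direction of the change therefore carries from one core to the other, but its size does not: the same change on two cores in this assay, a 20-fold higher number (1.31 log units; beyond the scatter) from compound 1 to compound 3 and a 7.1-fold higher number (0.85 log units; beyond the scatter) from compound 2 to compound 4, 2.9-fold (0.46 log units) apart, beyond the scatter of two such steps. Going by these compounds alone, with only one pair on each core, this does not show what sets the two steps apart, nor does it give a rule for any other core.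

The compounds shown leave open how methoxy or fluoro would compare with chloro and hydroxy on either core. They also leave open whether an amine in the same place would follow the same direction.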